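From a nitrophenyl to a trichlorophenyl on an aromatic nitrogen

A few compounds are considered here, and "the series" means these few. Any claim that something is new, unique, unknown or untested is made for them only; others in the source may bear on it.

Of the compounds shown here, three have been tested in a functional assay on HCT-116 cells (Homo sapiens) for antiproliferative activity, read by MTT assay, with a stated time of 48 h; a higher number here means a weaker inhibitor, a lower number a stronger inhibitor. Compound 1 `N#CC1=C(N)Oc2c(c3nc4ccccc4nc3c3ccccc23)C12C(=O)N(Cc1cnnn1-c1cccc(Br)c1)c1ccccc12` gives only a limit there, > 50000 nM. Compound 2 `N#CC1=C(N)Oc2c(c3nc4ccccc4nc3c3ccccc23)C12C(=O)N(Cc1cnnn1-c1ccc(F)c(Cl)c1)c1ccccc12` likewise gives only a limit, > 50000 nM. The step that the two limits leave unreadable from compound 1 to compound 2, 3-chloro-4-fluorophenyl in place of 3-bromophenyl on an aromatic nitrogen, therefore cannot be read. Compound 3 `N#CC1=C(N)Oc2c(N)cc3nc4ccccc4nc3c2C12C(=O)N(Cc1cnnn1-c1ccc([N+](=O)[O-])cc1)c1ccccc12` stands with the other two: in this assay compound 3 also gives a limit, > 50000 nM. Within the data shown here, all three values share (the limit of > 50000 nM in this assay, at which 3 of the 3 values shown sit), so no measured step of readable size exists in the set.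

Compound 4 `N#CC1=C(N)Oc2c(N)cc3nc4ccccc4nc3c2C12C(=O)N(Cc1cnnn1-c1c(Cl)cc(Cl)cc1Cl)c1ccccc12` differs from compound 3 by 2,4,6-trichlorophenyl in place of 4-nitrophenyl on an aromatic nitrogen. Among the measured compounds shown here, no measured step bears on this change, and the one step between measured compounds is unreadable. For the measured compounds named here, the only guide is that every tested compound, compound 3 among them, sits at the same limit of this assay. Compound 4 is therefore expected to remain near that limit, with an estimated step of a number no higher from compound 3 to compound 4 (the limit leaves the size open). The estimated value for compound 4 is 50000 nM, within 20000 nM and 200000 nM.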

Compound 4, half-maximal inhibitory concentration: 12100 nM
The estimate for compound 4 lay 4.1-fold (0.62 log units) above the measured number; the whole stated range lies above it.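

In this assay, the group on this aromatic nitrogen proves able to shift the result on the shared core: 2,4,6-trichlorophenyl in place of 4-nitrophenyl gives an at least 4.1-fold lower number from compound 3 to compound 4 (0.61 log units; beyond the scatter) in this series. Compound 4 is the only compound shown that gives a number rather than a limit, so the series is not uniformly inactive. The earlier compounds could not show this, and the one step between them cannot be read: the limit of > 50000 nM in this assay, at which 3 of the 4 values shown sit.

Going by these compounds, for compound 3 the value > 50000 nM is a limit, so the full size of the step remains open. Also open, on these data alone, is which of the three chlorine atoms of compound 4 matters, and what a phenyl bearing an amine or a carboxylic acid would give at this position.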